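Chloro for fluoro on the aryl urea of compound 2

The compounds below may be only part of what the source reports. "The series", "measured", "known", "first", "only" and "open" are said of these compounds alone.

Among the compounds with values here, compound 2 `O=C(Nc1cccc(CNc2ncnc3ccccc23)c1)Nc1ccccc1F` carries the only numerical reading in a functional assay on HepG2 cells (Homo sapiens) for antiproliferative activity, read by MTT assay; on this read-out higher numbers stand for weaker inhibition and lower numbers for stronger inhibition: compound 2 gives 17500 nM. Compound 1 `COc1ccc(NC(=O)Nc2cccc(CNc3ncnc4ccccc34)c2)cc1` reaches only the assay limit, and compound 1 is recorded as > 50000 nM in this assay. Within the data shown here, the single measured step, an at least 2.8-fold lower number from compound 1 to compound 2 (0.45 log units; beyond the scatter), is therefore bounded by the limit of > 50000 nM in this assay, at which 1 of the 2 values shown sits, and fixes only a minimum size. Compound 3 `O=C(Nc1cccc(CNc2ncnc3ccccc23)c1)Nc1ccccc1Cl` differs from compound 2 by chloro in place of fluoro on an aromatic carbon of a six-membered aromatic ring of carbon only, ortho to a large group. Among the measured compounds shown here, no measured step exchanges one halogen for another; the one step available alters a whole aryl substituent and does not bear directly on this change. In this assay no step beyond the scatter is expected, with at most a slight shift in either direction. Compound 3 is estimated at 12000 nM, within 4000 nM to 35000 nM. This corresponds to an expected step of a 1.5-fold lower number from compound 2 to compound 3 (0.16 log units; within the scatter).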

Compound 3, half-maximal inhibitory concentration: > 50000 nM
Compound 3: only a limit was reported; the forecaster's own chance of this, stated with the estimate: 10%; middle value at least 4.1-fold (0.61 log units) away from the limit.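

In this assay chloro in place of fluoro on an aromatic carbon, ortho to a large group, gives an at least 2.8-fold higher number from compound 2 to compound 3 (0.45 log units; beyond the scatter) and so marks this position as sensitive to a single halogen exchange on the aryl urea. Compound 3 gives > 50000 nM as a limit and not a number. The step from fluoro to chloro therefore fixes only a minimum size, and the step between the other two compounds cannot be read: the limit of > 50000 nM in this assay, at which 2 of the 3 values shown sit.

With compound 2 the only one of the three that gives a number, the reading rests on 2-fluorophenyl alone, and no trend across halogens can be drawn. Where an unsubstituted phenyl or a 2-methylphenyl on the same amide-type nitrogen would fall relative to compound 2 stays open.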